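The source may hold more compounds than are shown below. What is called first, only, known or untested is meant among the compounds shown, and "the series" means these compounds.

Compound 1 `O=C(NCCNc1nccc(-c2c(-c3cccc(F)c3)nc3sccn23)n1)c1c(F)cccc1F` carries a (2,6-difluorophenyl)carbonyl on the amine nitrogen of the shared core. In a functional assay on A-375 cells (Homo sapiens) for cytotoxicity, read by MTT assay (on this read-out higher numbers stand for weaker inhibition and lower numbers for stronger inhibition), compound 1 gives 2700 nM, the second highest of the three numbers recorded. Compound 2 `O=C(NCCNc1nccc(-c2c(-c3cccc(F)c3)nc3sccn23)n1)c1ccc(Cl)cc1`, with a 4-chlorophenyl on the carbonyl carbon, gives 2570 nM, and the step of a 1.1-fold lower number from compound 1 to compound 2 (0.02 log units; within the scatter) lies within the scatter. Compound 3 `O=S(=O)(NCCNc1nccc(-c2c(-c3cccc(F)c3)nc3sccn23)n1)c1ccccc1`, in which a phenylsulfonyl replaces the carbonyl group on the amine nitrogen, gives 11000 nM; the step of a 4.1-fold higher number from compound 1 to compound 3 (0.61 log units; beyond the scatter) and the step of a 4.3-fold higher number from compound 2 to compound 3 (0.63 log units; beyond the scatter) both lie beyond the scatter, so compound 3 is the weakest of the three.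

Compound 4 `Cc1ccc(C(=O)NCCNc2nccc(-c3c(-c4cccc(F)c4)nc4sccn34)n2)cc1` is the next member of the series. Relative to compound 1 the change is 4-methylphenyl in place of 2,6-difluorophenyl on a carbonyl carbon. Going by the values given here, the only measured step that bears on this change is the earlier exchange of the ring on the carbonyl carbon, a 1.1-fold lower number from compound 1 to compound 2 (0.02 log units; within the scatter), which stayed within the scatter; the two steps to the sulfonyl compound do not speak to a change of the ring alone. No step beyond the scatter is therefore expected for compound 4, a 1.0-fold lower number from compound 1 to compound 4 (0.02 log units; within the scatter). For compound 4 the expected value is 2600 nM, with a range from 1300 nM to 5500 nM.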

Compound 4, half-maximal inhibitory concentration: 5880 nM
Estimate against measurement, compound 4: 2.3-fold (0.35 log units) below, and the stated range ends below it.
By their numbers in this assay, from the lowest: compounds 2 and 1 (each within the scatter of the next); then compounds 4 and 3 (each within the scatter of the next).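

In this assay the ring on the carbonyl carbon proves not to be silent: the earlier exchange of rings stayed within the scatter, whereas this one gives (a 2.2-fold higher number from compound 1 to compound 4 (0.34 log units; beyond the scatter)). The smallest change in the set, methyl in place of chloro on an aromatic carbon, also gives a step beyond the scatter (a 2.3-fold higher number from compound 2 to compound 4 (0.36 log units; beyond the scatter)), so the substituent on this ring matters even when the ring itself is kept. Compound 4 also does not stand clear of the phenylsulfonyl compound (a 1.9-fold lower number from compound 3 to compound 4 (0.27 log units; within the scatter)), so the carbonyl compounds do not all separate from compound 3, and nothing available accounts for any of these steps.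

Open, going by these compounds, is how a 4-methoxyphenyl, a 4-trifluoromethylphenyl or a saturated cyclohexyl on the same carbonyl carbon would read. Also open, on these data alone, is whether a methyl on the phenylsulfonyl ring of compound 3 would shift its value.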